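From trifluoromethyl to fluoro on the benzyl ring

This account rests on a few compounds, and the source may have more. Where it says the series, first, only, none or still open, it means among the compounds named here.

Three compounds with a shared core were compared in a functional assay on HEK293 cells for agonist activity at G-protein coupled receptor 52 (Homo sapiens), read by cAMP accumulation, with a stated time of 15 min; a higher number here means that more compound is needed for the effect, a lower number that less compound is needed. Compound 1 `O=C(NCCO)c1cccc2c1CCN2c1ccnc(Cc2cc(F)cc(C(F)(F)F)c2)n1` gives 373 nM, compound 2 `Cc1c(Cc2cc(F)cc(C(F)(F)F)c2)cnnc1N1CCc2c(C(=O)NCCO)cccc21` gives 754 nM, and compound 3 `O=C(NCCO)c1cccc2c1CCN2c1cc(Cc2cccc(C(F)(F)F)c2)ncn1` gives 101 nM, the lowest of the three and beyond the scatter from both of the others. Compound 4 `O=C(NCCO)c1cccc2c1CCN2c1cc(Cc2cccc(F)c2)ncn1` has not been measured. It differs from compound 3 in one place: fluoro in place of trifluoromethyl on an aromatic carbon, on an aromatic carbon of a six-membered aromatic ring of carbon only. Within the data shown here, no measured pair shows this same change, so the expectation rests on compound 3 alone. The step of a 4.0-fold higher number from compound 3 to compound 4 (0.60 log units; beyond the scatter) is expected to point toward a higher number, beyond the scatter. Compound 4 is therefore estimated at 400 nM, within a range from 120 nM to 1500 nM.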

Compound 4, half-maximal effective concentration: 106 nM
The estimate for compound 4 lay 3.8-fold (0.58 log units) above the measured number, and the stated range ends above it.
By their numbers in this assay, from the lowest: compounds 3 and 4 (each within the scatter of the next); then compound 1; then compound 2.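

In this assay, fluoro in place of trifluoromethyl gives a 1.0-fold higher number from compound 3 to compound 4 (0.02 log units; within the scatter). Among these compounds, on this aromatic carbon, the group can thus go from 4 heavy atoms to 1 and the two compounds still cannot be told apart, which no earlier compound could show, since no measured pair carried this change. Nothing available here bears on why they read alike. On these data alone, what plain hydrogen, a chloro group or a methoxy group would give at this place remains open. So does whether the same change reads alike on the core of compound 1.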